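A few compounds are considered here, and "the series" means these few. Any claim that something is new, unique, unknown or untested is made for them only; others in the source may bear on it.

Working notes on the series.

Compound 1 `O=C1C=CC(OCC(F)(F)F)N1c1ccc(C(F)(F)F)cc1` and compound 2 `CC(C)c1ccc(N2C(=O)C=CC2OCC(F)(F)F)cc1` share the same core and differ only at one aromatic carbon. In a functional assay on HeLa cells (Homo sapiens) for inhibition (a lower number here means a stronger inhibitor, a higher number a weaker inhibitor), compound 1 gives 36200 nM; in this assay compound 2 gives 5800 nM. Among the compounds with values here, the single measured step, a 6.2-fold lower number from compound 1 to compound 2 (0.80 log units; beyond the scatter), is the only change at this position seen so far. On the two numbers available, compound 2 stands at the lowest value, with compound 1 the nearest, at a higher number that lies beyond the scatter.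

Compound 3 `Cc1ccc(N2C(=O)C=CC2OCC(F)(F)F)cc1` is not yet measured. The change from compound 2 to compound 3 is methyl in place of isopropyl on an aromatic carbon. Within the data shown here, no measured step covers a methyl at this position; the one step that bears on it, a 6.2-fold lower number from compound 1 to compound 2 (0.80 log units; beyond the scatter), shows that the group at this aromatic carbon can move the number in this assay by a modest amount, beyond the scatter. A methyl is smaller than the isopropyl it replaces and nearer in size to the trifluoromethyl of compound 1, so the number for compound 3 is expected to rise, though the direction is uncertain. The expected step is a 2.1-fold higher number from compound 2 to compound 3 (0.32 log units; beyond the scatter). Compound 3 is estimated at 12000 nM, with a range from 4000 nM to 40000 nM.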

Compound 3, half-maximal inhibitory concentration: 9380 nM
Compound 3: the middle estimate sits 1.3-fold (0.11 log units) above what was measured; the measured number falls inside the stated range.
By their numbers in this assay, from the lowest: compounds 2 and 3 (each within the scatter of the next); then compound 1.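

In this assay, methyl in place of isopropyl gives a 1.6-fold higher number from compound 2 to compound 3 (0.21 log units; within the scatter) and so does not separate these two groups at this aromatic carbon, para to a large group, although the group shrinks from 3 heavy atoms to 1. Methyl in place of trifluoromethyl gives a 3.9-fold lower number from compound 1 to compound 3 (0.59 log units; beyond the scatter) and so shows that the gap first seen with compound 1 is not tied to isopropyl alone: among the three groups shown, trifluoromethyl is the one set apart, with compound 2 and compound 3 on the same footing within the scatter. No supporting measurement is available to account for this separation.

Whether an amine, a methoxy group, a carboxylic acid or a longer chain at this aromatic carbon would stay with compound 2 and compound 3 or move the number beyond the scatter remains open, as the groups shown here are limited to isopropyl, methyl and trifluoromethyl. Going by these compounds, the trifluoroethoxy group is also the same in all three compounds, so what a plain ethoxy group or a hydroxyl group would do in its place on the shared core is equally open.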